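Phenoxy replacing 3-bromophenyl on the shared core

This account rests on a few compounds, and the source may have more. Where it says the series, first, only, none or still open, it means among the compounds named here.

Measured so far in a functional assay on Jurkat cells for inhibition of nuclear factor NF-kappa-B complex (Homo sapiens); a lower number here means a stronger inhibitor, a higher number a weaker inhibitor:
compound 1 `CCOC(=O)c1cnc(C(F)(F)F)nc1NN1C(=O)C=C(C)C1=O`: 1000 nM
compound 2 `CCOC(=O)c1cnc(-c2cccc(Br)c2)nc1NN1C(=O)C=C(C)C1=O`: 700 nM

Going by the values given here, compound 2 holds the lower of the two numbers, with compound 1 as its only neighbour; the one measured step, a 1.4-fold lower number from compound 1 to compound 2 (0.15 log units; within the scatter), alters the same position of the shared core and stays within the scatter. Compound 3 `CCOC(=O)c1cnc(Oc2ccccc2)nc1NN1C(=O)C=C(C)C1=O` carries a change at that position: phenoxy in place of 3-bromophenyl on an aromatic carbon. Among the compounds with values here, no measured step covers phenoxy, so only the modest step at this position informs the expectation, which is no change beyond the scatter, estimated as a 1.1-fold higher number from compound 2 to compound 3 (0.06 log units; within the scatter). For compound 3 in this assay the estimate is 800 nM, with a range of 300 nM to 2500 nM.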

Compound 3, half-maximal inhibitory concentration: 15000 nM
Beside the measured number, compound 3's estimate is 19-fold (1.27 log units) below it, and the stated range ends below it.
By their numbers in this assay, from the lowest: compounds 2 and 1 (each within the scatter of the next); then compound 3.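

In this assay this position turns out not to be indifferent: phenoxy in place of 3-bromophenyl gives a 21-fold higher number from compound 2 to compound 3 (1.33 log units; beyond the scatter), and phenoxy in place of trifluoromethyl gives a 15-fold higher number from compound 1 to compound 3 (1.18 log units; beyond the scatter). The two groups attached through carbon, in compound 1 and compound 2, lie within the scatter of each other, whereas compound 3, attached through oxygen, stands apart, though one compound makes no pattern. Nothing available explains this loss.

Still open, going by these compounds, is whether the loss follows the oxygen link or the missing bromine, which plain phenyl and 3-bromophenoxy would separate. Also open, on these data alone, is whether anilino or methoxy at this position behaves like phenoxy.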